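Swapping a Ring for an Open Chain

The source may hold more compounds than are shown below. What is called first, only, known or untested is meant among the compounds shown, and "the series" means these compounds.

Within the data shown here, in a physicochemical assay for lipophilicity, using the shake flask method, in phosphate buffer, measured as octanol-water partition, with a stated time of 30 min, at pH 7.4 (a higher number here means a more lipophilic compound, a lower number a more polar compound), compound 1 `CN(c1ncco1)c1cnc(NCc2c(F)ccc3c2CCO3)n2cnnc12` gives 2.1 and compound 2 `C[C@@H]1CC(=O)N(c2cnc(NCc3c(F)ccc4c3CCO4)n3cnnc23)C1` gives 1.8, so compound 2 stands within the usual scatter of the only other number available. The next compound, compound 3 `COCCC(=O)Nc1cnc(NCc2c(F)ccc3c2CCO3)n2cnnc12`, keeps the shared core and changes one place: ((2-methoxyethyl)carbonyl)amino in place of 4-methyl-2-oxopyrrolidin-1-yl on an aromatic carbon. In short, ((2-methoxyethyl)carbonyl)amino comes in place of 4-methyl-2-oxopyrrolidin-1-yl on an aromatic carbon, and the five-membered non-aromatic ring gives way to a group with no ring.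

Among the measured compounds shown here, only one measured step bears on this change. It involved a different pair of groups on the same aromatic carbon, and it was small: a number 0.30 log units lower from compound 1 to compound 2 (within the scatter). For the measured compounds named here, no measured step tests a swap from a ring to an open chain, and the entering group has a hydrogen-bond donor that the leaving group lacks, so this forecast rests on thin evidence. A small downward move is expected, and the estimated change in this assay is a number 0.30 log units lower from compound 2 to compound 3 (within the scatter). For compound 3 the estimated value is 1.5, with an expected range from 1 to 2.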

Compound 3, distribution coefficient: 1.4
The estimate for compound 3 lay 0.10 log units above the measured number; measured number inside the range.
By their numbers in this assay, from the lowest: compound 3; then compounds 2 and 1 (each within the scatter of the next).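

In this assay, among these compounds, ((2-methoxyethyl)carbonyl)amino gives the first step from the lactam-bearing compound that lies clear of the usual scatter, a number 0.40 log units lower from compound 2 to compound 3 (beyond the scatter), whereas the only earlier step at this aromatic carbon stayed within it. Set against the methyl(1,3-oxazol-2-yl)amino group, the same open chain gives a larger step, a number 0.70 log units lower from compound 1 to compound 3 (beyond the scatter), so the number in this assay does respond to the group placed at this position. Whether the loss of the five-membered ring, the added hydrogen-bond donor or the extra oxygen lies behind these steps is not settled by anything measured here.

Going by these compounds, how the number would respond to an amine or a carboxylic acid on this carbon stays open, as does whether a longer chain would carry it further in the same direction. Also open, on these data alone, is whether an open chain lacking the amide hydrogen would give a step of the same size, a comparison that would separate the ring from the hydrogen-bond donor.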